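The source may report more compounds than this note shows. Statements on the series, on what has been measured and on what is new or still open speak of the compounds shown alone.

Of the compounds shown here, three that share a core have been measured in a physicochemical assay for lipophilicity, read by HPLC, measured as octanol-water partition, with a stated time of 24 h, at pH 7.4; a lower number here means a more polar compound, a higher number a more lipophilic compound. Compound 1 `CCNC(=O)c1cc(N)c(Nc2ccc(C#N)cc2)cc1Oc1c(C)cc(CCC#N)cc1C` stands highest of the three at 3.63, compound 2 `Cc1cc(CCC#N)cc(C)c1Oc1cc(Nc2ccc(C#N)cc2)c(N)cc1CN(C)C` gives 2.52, and compound 3 `Cc1cc(CCC#N)cc(C)c1Oc1cc(Nc2ccc(C#N)cc2)c(N)cc1COC(=O)C1CC1` gives 2.51. The open case is compound 4 `COCc1cc(N)c(Nc2ccc(C#N)cc2)cc1Oc1c(C)cc(CCC#N)cc1C`, which differs from compound 1 as follows: methoxymethyl in place of ethylcarbamoyl on an aromatic carbon. In short, methoxymethyl takes the place of ethylcarbamoyl on an aromatic carbon.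

Two measured steps also remove ethylcarbamoyl from an aromatic carbon. The first is a number 1.11 log units lower from compound 1 to compound 2 (beyond the scatter), where (dimethylamino)methyl enters. The second is a number 1.12 log units lower from compound 1 to compound 3 (beyond the scatter), where ((cyclopropylcarbonyl)oxy)methyl enters. Both steps are large and point the same way. The third measured step, a number 0.01 log units lower from compound 2 to compound 3 (within the scatter), exchanges one entering group for the other and stays within the scatter.

Neither entering group is methoxymethyl, so these steps guide the expectation without settling it. A clear step to a lower number is expected in this assay, perhaps somewhat smaller than the two measured ones. The expected step is a number 0.93 log units lower from compound 1 to compound 4 (beyond the scatter). The estimate for compound 4 is 2.7, within an expected range of 2.2 to 3.4.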

Compound 4, partition coefficient: 3.25
Estimate against measurement, compound 4: 0.55 log units below; the measured number falls inside the stated range.
By their numbers in this assay, from the lowest: compounds 3 and 2 (each within the scatter of the next); then compound 4; then compound 1.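

In this assay the change from ethylcarbamoyl to methoxymethyl on this aromatic carbon gives a number 0.38 log units lower from compound 1 to compound 4 (beyond the scatter) and so shows that losing ethylcarbamoyl does not fix the size of the step, since what enters also counts. Compounds 2 and 3 lie within the scatter of each other and gave no sign that the end of the entering group matters, but with the same carbon attached to the ring, placing methyl instead of cyclopropylcarbonyl on the oxygen gives a number 0.74 log units higher from compound 3 to compound 4 (beyond the scatter) and methoxy instead of dimethylamino gives a number 0.73 log units higher from compound 2 to compound 4 (beyond the scatter) as a step of nearly the same size. Nothing at hand explains why methoxymethyl stands apart from the other two entering groups.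

The compounds shown leave open whether hydroxymethyl or a longer ether chain such as ethoxymethyl would fall nearer to compound 4 or nearer to compounds 2 and 3. They also leave open where a carboxylic acid or a primary amine on a carbon at this same place would stand in this order.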